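A few compounds are considered here, and "the series" means these few. Any claim that something is new, unique, unknown or untested is made for them only; others in the source may bear on it.

Among the compounds with values here, in a functional assay on MCF7 cells (Homo sapiens) for inhibition, read by sulforhodamine B assay, with a stated time of 48 h (a lower number here means a stronger inhibitor, a higher number a weaker inhibitor), compound 1 `COc1ccc(C(c2ccccc2O)c2cccc3ccccc23)c(OC)c1OC` gives 16600 nM, the only number among the three measured compounds. Compound 2 `COc1ccc(/C(=N/OC(C)=O)c2cccc3ccccc23)c(OC)c1OC` reaches only a limit of the assay, > 20000 nM. Compound 3 `CCOC(=O)CO/N=C(/c1ccc(OC)c(OC)c1OC)c1cccc2ccccc12` likewise reaches only a limit, > 20000 nM. Within the data shown here, the single measured step, a step that the two limits leave unreadable from compound 2 to compound 3, cannot be sized because both its values sit at the limit of > 20000 nM in this assay, at which 2 of the 3 values shown sit. Compound 4 `COc1ccc(C(c2ccc(OCC(=O)O)cc2)c2cccc3ccccc23)c(OC)c1OC` differs from compound 1 by 4-(carboxymethoxy)phenyl in place of 2-hydroxyphenyl on a saturated chain carbon bound to two aromatic carbons. Among the measured compounds shown here, that measured step concerns an oxygen substituent elsewhere, not this carbon, so no measured step bears on the change to compound 4. The step of a 1.0-fold higher number from compound 1 to compound 4 (0.01 log units; within the scatter) is therefore expected to stay within the usual scatter. Compound 4 is accordingly estimated at 17000 nM, in a range from 7000 nM to 40000 nM.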

Compound 4, half-maximal inhibitory concentration: > 20000 nM
Compound 4: a limit, no number (the forecaster's own chance of this, stated with the estimate: 40%); at least 1.1-fold (0.07 log units) between middle value and limit.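

In this assay, the change on the saturated chain carbon bound to two aromatic carbons gives an at least 1.2-fold higher number from compound 1 to compound 4 (0.08 log units; that floor lies within the scatter), the first step read at this position. From the compounds shown here alone, only a floor is given, so 4-(carboxymethoxy)phenyl shows no gain over 2-hydroxyphenyl, and the true size of the step remains unknown. Compound 4 gives a limit and not a number, and it joins most of the set there: the limit of > 20000 nM in this assay, at which 3 of the 4 values shown sit.

Going by these compounds, it remains open whether the loss of the hydroxyl or the arrival of the carboxymethoxy chain matters more. Also open, on these data alone, is whether a plain phenyl or a phenyl bearing an amine on this carbon would give a readable number.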